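The compounds below may be only part of what the source reports. "The series", "measured", "known", "first", "only" and "open" are said of these compounds alone.

Measured in an assay on SK-BR-3 cells for inhibition of Aromatase (Homo sapiens); a higher number here means a weaker inhibitor, a lower number a stronger inhibitor:
compound 1 `CS(=O)(=O)Nc1ccc([N+](=O)[O-])cc1OCc1ccc2ccccc2c1`: 2170 nM
compound 2 `CC(C)c1ccc(COc2cc([N+](=O)[O-])ccc2NS(C)(=O)=O)cc1`: 7450 nM

Compound 2 stands highest of the two numbers in this assay; the nearest, compound 1, sits lower by a margin beyond the usual scatter, so compound 2 is the weaker of the two measured. Going by the values given here, the two differ in the whole group carried on the ether oxygen, and no single-point step between measured compounds is available.

Compound 3 `CS(=O)(=O)Nc1ccc([N+](=O)[O-])cc1OCc1ccc(-c2ccccc2)cc1` is the next point. It differs from compound 2 by phenyl in place of isopropyl on an aromatic carbon. Among the compounds with values here, no measured pair covers this change, so the expectation rests on compound 1, whose larger aromatic group on the ether gives 2170 nM, a lower number than compound 2.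

The step from compound 2 to compound 3 is expected to lower the number beyond the scatter, roughly toward where compound 1 lies, as a 2.5-fold lower number from compound 2 to compound 3 (0.40 log units; beyond the scatter). Compound 3 is accordingly estimated at 3000 nM, with a range from 1200 nM to 8000 nM; the direction is more confident than the size.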

Compound 3, half-maximal inhibitory concentration: 850 nM
The estimate for compound 3 lay 3.5-fold (0.55 log units) above the measured number; the measured number lies below the stated range.
By their numbers in this assay, from the lowest: compound 3; then compound 1; then compound 2.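

In this assay, going by these compounds alone, phenyl in place of isopropyl on an aromatic carbon, para to a large group, gives an 8.8-fold lower number from compound 2 to compound 3 (0.94 log units; beyond the scatter), the first single-point step, so the number responds to the group held at this position. The change adds heavy atoms and a six-membered aromatic ring of carbon only, with no hydrogen-bond donors or acceptors on either side, so the step involves no gain of such atoms. Nothing available bears on why the number falls with this change.

From the compounds shown here alone, whether the step needs an aromatic ring or only a larger group stays open: a cyclohexyl group or a longer chain at this position would separate the two, while an amine or a methoxy group there would show how the number responds to a group carrying heteroatoms. One step from a single pair also leaves open whether the same change would hold on an altered core.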